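A few compounds are considered here, and "the series" means these few. Any claim that something is new, unique, unknown or untested is made for them only; others in the source may bear on it.

Measured so far:
compound 1 `CCOc1ccccc1-n1nncc1CN1C(=O)C2(C(C#N)=C(N)Oc3c2c2nc4ccccc4nc2c2ccccc32)c2ccccc21` — > 50000 nM
compound 2 `CC(=O)Nc1ccc(-n2nncc2CN2C(=O)C3(C(C#N)=C(N)Oc4c(N)cc5nc6ccccc6nc5c43)c3ccccc32)cc1` — > 50000 nM

Both values are limits of the assay, not numbers. In a functional assay on A549 cells (Homo sapiens) for antiproliferative activity, read by MTT assay, with a stated time of 48 h (a lower number here means a stronger inhibitor, a higher number a weaker inhibitor), compound 1 returns only a limit, > 50000 nM. In this assay compound 2 likewise returns only a limit, > 50000 nM. Compound 2 therefore stands at the limit and nowhere else, as shown by the limit of > 50000 nM in this assay, at which 2 of the 2 values shown sit. Compound 3 `N#CC1=C(N)Oc2c(N)cc3nc4ccccc4nc3c2C12C(=O)N(Cc1cnnn1-c1ccc(Cl)cc1[N+](=O)[O-])c1ccccc12` follows from compound 2 by one change: 4-chloro-2-nitrophenyl in place of 4-acetamidophenyl on an aromatic nitrogen. Going by the values given here, no step between measured compounds is available, so no direction beyond the scatter can be read from the series. Compound 3 is expected to stay at the limit, the step that the limit leaves unreadable from compound 2 to compound 3 being none beyond the scatter. The estimate for compound 3 is 60000 nM, between 20000 nM and 200000 nM.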

Compound 3, half-maximal inhibitory concentration: > 50000 nM
Compound 3: no number, only a limit (the forecaster's own chance of this, stated with the estimate: 80%); the middle value does not contradict the limit.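

No step can be read from compound 2 to compound 3, since both values are limits and not numbers: the limit of > 50000 nM in this assay, at which 3 of the 3 values shown sit.

The compounds shown leave open whether 4-acetamidophenyl and 4-chloro-2-nitrophenyl differ at all in this assay, and which change to the shared core would give a measurable number.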